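The compounds below may be only part of what the source reports. "The series", "measured", "known", "first", "only" and "open" are said of these compounds alone.

Compound 1, `O=C(CN1CCCC1)Nc1ccc2ncnc(Nc3cccc(Br)c3)c2c1`, was tested in a functional assay on HepG2 cells (Homo sapiens) for antiproliferative activity, read by MTT assay, with a stated time of 48 h (on this read-out higher numbers stand for weaker inhibition and lower numbers for stronger inhibition), and gave only a limit of the assay, > 100000 nM. Compound 2, `O=C(CN1CCCCC1)Nc1ccc2ncnc(Nc3cccc(Br)c3)c2c1`, differs from it by piperidin-1-yl in place of pyrrolidin-1-yl on a saturated chain carbon bound to a carbonyl carbon and in this assay gives 16000 nM. The step is an at least 6.2-fold lower number from compound 1 to compound 2 (0.79 log units; beyond the scatter). Because the limit of > 100000 nM in this assay, at which 2 of the 3 values shown sit, sits beneath this step, its true size is not known, only that it is at least this large.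

Compound 3, `O=C(CN1CCCC1)Nc1ccc2ncnc(Nc3ccc(Cl)c(C(F)(F)F)c3)c2c1`, carries a different core; how it differs from the core of compound 1 is not broken down here. In this assay compound 3 also returns only a limit, > 100000 nM.

Compound 4, `O=C(CN1CCCCC1)Nc1ccc2ncnc(Nc3ccc(Cl)c(C(F)(F)F)c3)c2c1`, has not yet been measured in this assay. It stands to compound 3 as compound 2 stands to compound 1: the change is piperidin-1-yl in place of pyrrolidin-1-yl on a saturated chain carbon bound to a carbonyl carbon, the same change at the same place.

The step from compound 3 to compound 4 is expected to be an at least 2.5-fold lower number from compound 3 to compound 4 (0.39 log units; beyond the scatter), which rests on the step of an at least 6.2-fold lower number from compound 1 to compound 2 (0.79 log units; beyond the scatter) seen on the other core, tempered by the fact that compound 3 starts from a limit and that the step on the first core is itself known only as a lower bound. On that basis compound 4 is expected to give about 40000 nM in this assay, within a range from 8000 nM to 200000 nM, with a real chance that the assay again reports only a limit.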

Compound 4, half-maximal inhibitory concentration: > 100000 nM
Compound 4: only a limit was reported; the forecaster's own chance of this, stated with the estimate: 45%; middle value at least 2.5-fold (0.39 log units) away from the limit.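

No step from compound 3 to compound 4 can be read in this assay, because both compounds return only a limit of the assay: the limit of > 100000 nM in this assay, at which 3 of the 4 values shown sit.

The compounds shown leave open whether piperidin-1-yl in place of pyrrolidin-1-yl lowers the number on the core of compound 3 as it does on the core of compound 1, and what the true values of compound 1, compound 3 and compound 4 are.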